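Moving a chlorine within a sulfonamide series

The source may report more compounds than this note shows. Statements on the series, on what has been measured and on what is new or still open speak of the compounds shown alone.

The measure throughout is a functional assay on DLD-1 cells (Homo sapiens) for antiproliferative activity, read by CellTiter-Glo, with a stated time of 72 h; a lower number here means a stronger inhibitor, a higher number a weaker inhibitor. Compound 1 `CC1CCN(C2CCN(S(=O)(=O)c3cccnc3Cl)CC2)CC1` is the one that sits at the limit of > 5000 nM in this assay, at which 1 of the 3 values shown sits. In this assay compound 1 gives > 5000 nM, a limit of the assay rather than a number, so its true strength is known only to be weak. The two other measured compounds give numbers: compound 2 `Cc1cc(C)c(S(=O)(=O)N2CCC(N3CCN(C)CC3)CC2)c(C)c1` gives 1100 nM in this assay, and compound 3 `CC1CCN(C2CCN(S(=O)(=O)c3ccc(Cl)c4ccccc34)CC2)CC1` gives 0.1 nM. For the measured compounds named here, neither compound 2 nor compound 3 differs from compound 1 in a single place, so no measured step describes what a small rearrangement of the sulfonyl ring does here.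

Compound 4 `CC1CCN(C2CCN(S(=O)(=O)c3ccc(Cl)nc3)CC2)CC1` differs from compound 1 in one place: 6-chloropyridin-3-yl in place of 2-chloropyridin-3-yl on a sulfonyl sulfur. Going by the values given here, nothing among the measured compounds anchors the size of this change. The expectation rests on compound 1 alone, which gives > 5000 nM, and is for a step no larger than the scatter, in either direction; the step from compound 1 to compound 4 is therefore estimated as an at least 1.2-fold lower number from compound 1 to compound 4 (0.09 log units; that floor lies within the scatter). Compound 4 is estimated to give 4000 nM in this assay, with a range from 600 nM to 20000 nM, and a fair chance that only a limit is reported.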

Compound 4, half-maximal inhibitory concentration: 3700 nM
Compound 4: the middle estimate sits 1.1-fold (0.03 log units) above what was measured; the measured number falls inside the stated range.
By their numbers in this assay, from the lowest: compound 3; then compound 2; then compound 4. At a limit, above all of these: compound 1.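

In this assay, exchanging 2-chloropyridin-3-yl for 6-chloropyridin-3-yl on a sulfonyl sulfur, with the same atoms joined differently, gives an at least 1.3-fold lower number from compound 1 to compound 4 (0.13 log units; that floor lies within the scatter). This is the only step shown that isolates a change at this place on the shared core, and its printed floor does not establish a change beyond the usual scatter. Because one end of the step is an assay limit, only that floor is known and the true size of the step cannot be read from these compounds: the limit of > 5000 nM in this assay, at which 1 of the 4 values shown sits.

The compounds shown leave open what a methoxy group or a nitrile in place of the chlorine on the 6-chloropyridin-3-yl ring would do in this assay. They also leave open whether the same move of a chlorine on another sulfonyl ring would give a step of any size.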